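A few compounds are considered here, and "the series" means these few. Any claim that something is new, unique, unknown or untested is made for them only; others in the source may bear on it.

Compound 1 `COc1cc(-c2nn(-c3cccc(NC(=O)Nc4ccc(Cl)c(Cl)c4)c3)cc2-c2ccncc2)ccc1Cl` stands in a functional assay on NCI-H226 cells (Homo sapiens) for inhibition, read by sulforhodamine B assay, with a stated time of 48 h (on this read-out higher numbers stand for weaker inhibition of growth and lower numbers for stronger inhibition of growth), at 1350 nM, the second highest of three numbers, all within the scatter of one another. Compound 2 `O=C(Nc1cccc(-n2cc(-c3ccncc3)c(-c3ccc(Cl)c(O)c3)n2)c1)Nc1ccc(Cl)c(Cl)c1` gives 1510 nM, and compound 3 `O=C(Nc1cccc(-n2cc(-c3ccncc3)c(-c3ccc(Cl)c(O)c3)n2)c1)Nc1cc(C(F)(F)F)cc(C(F)(F)F)c1` gives 1240 nM. Going by the values given here, the only measured single step, a 1.1-fold higher number from compound 1 to compound 2 (0.05 log units; within the scatter), changes nothing beyond the scatter. Compound 4 `COc1cc(-c2nn(-c3cccc(NC(=O)c4ccccc4)c3)cc2-c2ccncc2)ccc1Cl` differs from compound 1 by phenyl in place of (3,4-dichlorophenyl)amino on a carbonyl carbon. Among the compounds with values here, no measured step covers this change; the values of compound 2 and compound 3 show no gap beyond the scatter, and neither compound lacks the (3,4-dichlorophenyl)amino group. The expectation is therefore weakly founded, with a somewhat higher number for compound 4 estimated, a 2.6-fold higher number from compound 1 to compound 4 (0.41 log units; beyond the scatter). Compound 4 is expected near 3500 nM, between 1200 nM and 12000 nM.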

Compound 4, concentration for 50% growth inhibition: 2350 nM
Compound 4: middle estimate off by 1.5-fold (0.17 log units), on the high side, within the range that was stated.
By their numbers in this assay, from the lowest: compounds 3, 1, 2 and 4 (each within the scatter of the next).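

Phenyl in place of (3,4-dichlorophenyl)amino on a carbonyl carbon gives a 1.7-fold higher number from compound 1 to compound 4 (0.24 log units; within the scatter), so the first change measured at this place stays inside the scatter. With the chlorine atoms and the hydrogen-bond donor of the (3,4-dichlorophenyl)amino group gone, compound 4 still reads alongside compound 1. No measurement on hand gives a reason for this result. Open remains how a longer alkyl chain on the same carbonyl carbon would read, or a phenyl carrying an amine or a carboxylic acid.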